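A few compounds are considered here, and "the series" means these few. Any claim that something is new, unique, unknown or untested is made for them only; others in the source may bear on it.

Measured in a physicochemical assay for solubility, measured as kinetic solubility, with a stated time of 1 h, at pH 7.4; a lower number here means a less soluble compound, a higher number a more soluble compound:
- compound 1 `O=C(NC1=NN(c2ccc(Cl)c(Cl)c2)CC1)c1cncnc1`: 8000 nM
- compound 2 `CC(=O)NC1=NN(c2ccc(Cl)c(Cl)c2)C[C@H]1C`: 36000 nM
- compound 3 `CC(=O)NC1=NN(c2ccc(Cl)c(Cl)c2)C[C@@H]1C`: 32000 nM

Compound 3 sits level with compound 2 within the scatter, while the value of compound 1 lies clearly lower, beyond the scatter.

Next is compound 4 `C[C@H]1CN(c2ccc(Cl)c(Cl)c2)N=C1NC(=O)c1cncnc1`, which differs from compound 3 as follows: pyrimidin-5-yl in place of methyl on a carbonyl carbon. In words, pyrimidin-5-yl replaces methyl on a carbonyl carbon.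

Among the measured compounds shown here, the only measured step is a 1.1-fold lower number from compound 2 to compound 3 (0.05 log units; within the scatter). It concerns (the fact that compounds 2 and 3 differ only in the configuration as drawn), so it gives no size for this exchange. The nearest guide is compound 1 at 8000 nM, which carries the same pyrimidin-5-yl but has no methyl on the saturated ring carbon. The effect of that methyl has not been measured, so the range is kept wide.

In this assay a lower number is expected, beyond the scatter, with the expected step being a 4.6-fold lower number from compound 3 to compound 4 (0.66 log units; beyond the scatter).

For compound 4 the estimated value is 7000 nM, with an expected range of 2500 nM to 20000 nM.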

Compound 4, solubility: 9000 nM
Estimate against measurement, compound 4: 1.3-fold (0.11 log units) below; low and high end bracket the measured number.
By their numbers in this assay, from the lowest: compounds 1 and 4 (each within the scatter of the next); then compounds 3 and 2 (each within the scatter of the next).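

In this assay, the exchange on a carbonyl carbon now has a measured size, with pyrimidin-5-yl in place of methyl as the only difference (a 3.6-fold lower number from compound 3 to compound 4 (0.55 log units; beyond the scatter)). With pyrimidin-5-yl in place, methyl in place of hydrogen on a saturated ring carbon leaves the number level (a 1.1-fold higher number from compound 1 to compound 4 (0.05 log units; within the scatter)), so in this pair the methyl does not shift the reading beyond the scatter. No measured property in hand accounts for either step.

Still open, on these data alone, is how an amine, a carboxylic acid or a longer alkyl chain on the carbonyl carbon would read in this assay. Also open, as far as these compounds go, is whether the exchange to pyrimidin-5-yl gives a step of similar size with the opposite configuration at the saturated ring carbon.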